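Swapping the aryl group on a tetrabromobenzotriazole alcohol

The source may hold more compounds than are shown below. What is called first, only, known or untested is meant among the compounds shown, and "the series" means these compounds.

Of the compounds shown here, three sharing one core have been tested in a functional assay on CCRF-CEM cells (Homo sapiens) for antiproliferative activity, read by MTT assay, with a stated time of 24 h, tested at 12.5 uM; on this read-out lower numbers stand for a stronger effect and higher numbers for a weaker effect at the one concentration tested. Compound 1 `COc1cccc(C(O)CCn2nc3c(Br)c(Br)c(Br)c(Br)c3n2)c1` gives 110% in this assay. Compound 2 `C[C@@H](O)CCn1nc2c(Br)c(Br)c(Br)c(Br)c2n1` gives 88%, and compound 3 `C[C@H](O)CCn1nc2c(Br)c(Br)c(Br)c(Br)c2n1` gives 126%. Compound 1 thus holds the second highest of the three numbers: compound 3 sits above it, and compound 2 sits below it, both by more than the usual scatter.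

Going by the values given here, the one measured step is a number 38 percentage points higher from compound 2 to compound 3 (beyond the scatter), a large change that arises from the fact that compounds 2 and 3 differ only in the configuration as drawn; it carries no information about the aromatic group on the chain.

Compound 4 `OC(CCn1nc2c(Br)c(Br)c(Br)c(Br)c2n1)c1ccc(Br)cc1` is the next compound and differs from compound 1 in one place: 4-bromophenyl in place of 3-methoxyphenyl on a saturated chain carbon bound to an oxygen on a saturated carbon and a saturated chain carbon. Among the compounds with values here, no measured pair touches this kind of change, so no direction can be drawn from the earlier numbers. The expectation is therefore a step of a number 5 percentage points lower from compound 1 to compound 4 (within the scatter), that is, nothing beyond the scatter. Compound 4 is estimated to give 105% in this assay, with a likely range from 80% to 130%, reflecting how widely even closely related compounds have spread here.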

Compound 4, a percentage reported as activity, at one concentration (the size of the read-out at that concentration, not a potency): 101%
The estimate for compound 4 lay 4 percentage points above the measured number; low and high end bracket the measured number.
By their numbers in this assay, from the lowest: compound 2; then compounds 4 and 1 (each within the scatter of the next); then compound 3.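

In this assay, going by these compounds alone, this swap gives the first reading on the aromatic group itself, and the change stays inside the usual noise: a number 9 percentage points lower from compound 1 to compound 4 (within the scatter). At this saturated chain carbon, then, 4-bromophenyl and 3-methoxyphenyl cannot be told apart in this read-out, even though the swap removes the hydrogen-bond acceptor counted for the leaving group and brings in a bromine. Nothing measured here bears on why the two groups read alike.

As far as these compounds go, compounds 1 and 4 both carry a substituted six-membered aromatic ring at this place, so it remains open how an unsubstituted phenyl ring, an amine, a carboxylic acid or a longer chain would read there. Compounds 1 and 4 are also drawn without a configuration at the saturated chain carbon bound to the oxygen, and the separate forms of each remain open, although configuration alone accounts for the much larger change seen with a number 38 percentage points higher from compound 2 to compound 3 (beyond the scatter).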